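The source may hold more compounds than are shown below. What is called first, only, known or untested is meant among the compounds shown, and "the series" means these compounds.

Of the compounds shown here, three built on one shared core have been measured in a functional assay on A549 cells (Homo sapiens) for antiproliferative activity, read by MTT assay, with a stated time of 48 h; a higher number here means a weaker inhibitor, a lower number a stronger inhibitor. Compound 1 `O=C(/C=C/c1ccccc1)Nc1nnc(-c2ccc(Br)cc2)s1` gives 2.18 ug/mL; compound 2 `Cc1ccc(/C=C/C(=O)Nc2nnc(-c3ccc(Br)cc3)s2)cc1` gives 1.51 ug/mL; compound 3 `O=C(/C=C/c1ccc(C(F)(F)F)cc1)Nc1nnc(-c2ccc(Br)cc2)s1` gives 4.68 ug/mL. Compound 2 has the lowest of the three numbers, though a 1.4-fold lower number from compound 1 to compound 2 (0.16 log units; within the scatter) lies within the scatter, while a 2.1-fold higher number from compound 1 to compound 3 (0.33 log units; beyond the scatter) and a 3.1-fold higher number from compound 2 to compound 3 (0.49 log units; beyond the scatter) lie beyond it, both modest. Compound 4 `COc1ccc(-c2nnc(NC(=O)/C=C/c3ccc(C)cc3)s2)cc1` differs from compound 2 by methoxy in place of bromo on an aromatic carbon, which read one bond further out is 4-bromophenyl to 4-methoxyphenyl. All three measured steps alter the other aromatic ring, so none bears directly on this change, and even those were only modest in size. In this assay compound 4 is therefore expected to give 1.8 ug/mL, between 0.7 ug/mL and 4.5 ug/mL, an expected step of a 1.2-fold higher number from compound 2 to compound 4 (0.08 log units; within the scatter), not beyond the scatter.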

Compound 4, half-maximal inhibitory concentration: 0.58 ug/mL
Beside the measured number, compound 4's estimate is 3.1-fold (0.49 log units) above it, and the stated range ends above it.
By their numbers in this assay, from the lowest: compound 4; then compounds 2 and 1 (each within the scatter of the next); then compound 3.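

The ring that carries bromo in compound 2 proves responsive in this assay: methoxy in place of bromo gives a 2.6-fold lower number from compound 2 to compound 4 (0.42 log units; beyond the scatter), the first step shown at this position. The change sits para to a large group and adds one hydrogen-bond acceptor, and it moves the number beyond the scatter. No measurement at hand gives a reason for this step.

As far as these compounds go, only bromo and methoxy have stood here, so it remains open how a hydroxyl, an amine or a fluoro would read at this position. From the compounds shown here alone, whether methoxy gives a similar step alongside the trifluoromethyl of compound 3 also remains open.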